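What a methoxy group may do to compound 3

This account rests on a few compounds, and the source may have more. Where it says the series, first, only, none or still open, it means among the compounds named here.

In an ADME assay on MT4 cells (Homo sapiens) for cytotoxicity, read by MTT assay, with a stated time of 4 days (a lower number here means that less compound is tolerated, a higher number that more compound is tolerated), compound 1 `CC(=O)Nc1ccc2oc(-c3ccccc3)c(O)c(=O)c2c1` gives 64700 nM, compound 2 `COc1ccccc1-c1oc2ccc(NC(C)=O)cc2c(=O)c1O` gives 385000 nM, and compound 3 `Nc1ccc2oc(-c3ccccc3)c(O)c(=O)c2c1` gives 217000 nM. Compound 3 therefore lies within the usual scatter of compound 2 and clearly apart from compound 1, which has the lowest number of the three.

Compound 4 `COc1ccccc1-c1oc2ccc(N)cc2c(=O)c1O` differs from compound 3 by one change: methoxy in place of hydrogen on an aromatic carbon. This is methoxy in place of hydrogen on an aromatic carbon, ortho to a large group.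

The same swap has been measured once, as a 6.0-fold higher number from compound 1 to compound 2 (0.77 log units; beyond the scatter). The other measured step, a 3.4-fold higher number from compound 1 to compound 3 (0.53 log units; beyond the scatter), removes the acetyl group from the nitrogen and also raises the number. Compound 3 already carries that rise, and nothing yet shows whether the two rises add up. A single example is also thin evidence. A smaller rise in the same direction is therefore expected, an estimated 2.2-fold higher number from compound 3 to compound 4 (0.34 log units; beyond the scatter). In this assay, the estimate for compound 4 is 480000 nM, with an expected range from 190000 nM to 1200000 nM.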

Compound 4, half-maximal cytotoxic concentration: 222000 nM
Compound 4: the middle estimate sits 2.2-fold (0.33 log units) above what was measured; the measured number falls inside the stated range.
By their numbers in this assay, from the lowest: compound 1; then compounds 3, 4 and 2 (each within the scatter of the next).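

With hydrogen in place of acetyl on the nitrogen, the methoxy swap gives only a 1.0-fold higher number from compound 3 to compound 4 (0.01 log units; within the scatter) in this assay, so its effect on this aromatic carbon depends on what the nitrogen carries: the same change on two cores in this assay, a 6.0-fold higher number (0.77 log units; beyond the scatter) from compound 1 to compound 2 and a 1.0-fold higher number (0.01 log units; within the scatter) from compound 3 to compound 4, 5.8-fold (0.76 log units) apart, beyond the scatter of two such steps

Removing the acetyl group also behaves differently once methoxy is present, giving a 1.7-fold lower number from compound 2 to compound 4 (0.24 log units; within the scatter): the same change on two cores in this assay, a 3.4-fold higher number (0.53 log units; beyond the scatter) from compound 1 to compound 3 and a 1.7-fold lower number (0.24 log units; within the scatter) from compound 2 to compound 4, 5.8-fold (0.76 log units) apart, beyond the scatter of two such steps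

The two changes therefore do not add up: each raises the number from compound 1, but adding the second brings no further step beyond the scatter.

From the compounds shown here alone, whether ethoxy or a chlorine atom on this same carbon would behave like methoxy remains open. So does whether a longer acyl chain on the nitrogen would make the methoxy swap count as it does with acetyl.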